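The source may report more compounds than this note shows. Statements on the series, on what has been measured and on what is new or still open speak of the compounds shown alone.

Measured so far in a functional assay on NCI-H727 cells (Homo sapiens) for cytotoxicity, read by cell counting, with a stated time of 48 h; a higher number here means a weaker inhibitor, a lower number a stronger inhibitor:
compound 1 `Clc1ccc(-n2cc(COc3cccc4cnc(Nc5cccc(Cl)c5)nc34)nn2)cc1` gives > 25000 nM (a limit)
compound 2 `Clc1cccc(Nc2ncc3cccc(OCc4cn(Cc5c(Cl)cccc5Cl)nn4)c3n2)c1` gives 5000 nM (a number)

Compound 1 has no number, only a limit (the limit of > 25000 nM in this assay, at which 1 of the 2 values shown sits). Compound 3 `COc1cccc(-n2cc(COc3cccc4cnc(Nc5cccc(Cl)c5)nc34)nn2)c1` keeps the core of compound 1 and carries 3-methoxyphenyl in place of 4-chlorophenyl on an aromatic nitrogen. Among the measured compounds shown here, one measured step bears on this place: an at least 5.0-fold lower number from compound 1 to compound 2 (0.69 log units; beyond the scatter) with 2,6-dichlorobenzyl entering there. It is a loose guide, since compound 2 carries a benzyl group while compound 3 keeps a phenyl group, as compound 1 does. Set against the step to compound 2 (an at least 5.0-fold lower number from compound 1 to compound 2 (0.69 log units; beyond the scatter)), a smaller step is expected in this assay, towards a slightly lower number or none beyond the scatter. The estimated step reads an at least 1.2-fold lower number from compound 1 to compound 3 (0.09 log units; that floor lies within the scatter) and is expected to be uncertain, as it starts from a limit. Compound 3 is estimated at 20000 nM with an expected range of 7000 nM to 40000 nM in this read-out, and a further limit would be no surprise.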

Compound 3, half-maximal inhibitory concentration: > 25000 nM
Compound 3 was reported as a limit; the forecaster's own chance of this, stated with the estimate: 50%; middle value at least 1.2-fold (0.09 log units) away from the limit.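

In this assay the reading for compound 3 is a limit, as is the reading for compound 1, so the step between these two compounds cannot be read, and the exchange of 4-chlorophenyl for 3-methoxyphenyl has no measurable size here: the limit of > 25000 nM in this assay, at which 2 of the 3 values shown sit.

Against the benzyl compound the picture is clearer, with 3-methoxyphenyl in place of 2,6-dichlorobenzyl on the aromatic nitrogen giving an at least 5.0-fold higher number from compound 2 to compound 3 (0.69 log units; beyond the scatter). Two phenyl groups with different substituents now both end at a limit, and among the three compounds shown, only compound 2, with its benzyl group, gives a number.

On these data alone, it remains open whether the difference follows the methylene link of the benzyl group or the chlorine atoms of 2,6-dichlorobenzyl, since compound 2 differs from both phenyl compounds in both respects. An unsubstituted benzyl group would separate these two features, and a longer chain such as 2-phenylethyl on the same nitrogen would show whether the trend continues beyond the benzyl group.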